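Benzodioxinyl to Naphthyl on the Amine-Bound Chain Carbon

The source may hold more compounds than are shown below. What is called first, only, known or untested is meant among the compounds shown, and "the series" means these compounds.

Of the compounds shown here, three sharing one sulfonamide core have been tested in a functional assay on A2780 cells (Homo sapiens) for inhibition, read by MTT assay, with a stated time of 72 h; a higher number here means a weaker inhibitor of growth, a lower number a stronger inhibitor of growth. Compound 1 `O=S(=O)(NCCNCc1ccc(-c2ccccc2)cc1)c1cc(C(F)(F)F)cc(C(F)(F)F)c1` gives 2600 nM, compound 2 `O=S(=O)(NCCCNCc1ccc(Cl)c(C(F)(F)F)c1)c1cc(C(F)(F)F)cc(C(F)(F)F)c1` gives 5900 nM, and compound 3 `O=S(=O)(NCCCNCC1COc2ccccc2O1)c1cc(C(F)(F)F)cc(C(F)(F)F)c1` gives 1500 nM. For the measured compounds named here, compound 3 carries the lowest of the three numbers, though compound 1 sits within the scatter of it, and the only step between single-point neighbours, a 3.9-fold lower number from compound 2 to compound 3 (0.59 log units; beyond the scatter), is modest yet beyond the scatter. Compound 4 `O=S(=O)(NCCCNCc1cccc2ccccc12)c1cc(C(F)(F)F)cc(C(F)(F)F)c1` differs from compound 3 by naphthalen-1-yl in place of 2,3-dihydro-1,4-benzodioxin-2-yl on a saturated chain carbon bound to an amine nitrogen. Going by the values given here, no measured step covers this particular exchange; the step from compound 2 to compound 3 involves a different entering group and shows only that the group on that chain carbon can shift the number by a modest amount. Compound 2, whose group at that place likewise has no oxygen, gives a higher number than compound 3, while compound 1 lies within the scatter. A small upward step, a 2.0-fold higher number from compound 3 to compound 4 (0.30 log units; within the scatter), is therefore expected. Compound 4 is estimated at 3000 nM, within a range from 1200 nM to 8000 nM.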

Compound 4, concentration for 50% growth inhibition: 3100 nM
Beside the measured number, compound 4's estimate is 1.0-fold (0.01 log units) below it, within the range that was stated.
By their numbers in this assay, from the lowest: compounds 3, 1, 4 and 2 (each within the scatter of the next, the first and the last beyond it).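

In this assay, naphthalen-1-yl and 2,3-dihydro-1,4-benzodioxin-2-yl hold the same count of heavy atoms, yet the exchange gives a 2.1-fold higher number from compound 3 to compound 4 (0.32 log units; beyond the scatter), a modest step beyond the scatter. Size by heavy-atom count therefore does not settle the number at this place on a saturated chain carbon bound to an amine nitrogen. For the compounds shown here, the second all-carbon-ring comparison gives a 1.9-fold lower number from compound 2 to compound 4 (0.28 log units; within the scatter), which stays within the scatter, so among compounds 2, 3 and 4 only compound 3, the one whose group contains oxygen, stands apart from both others.

Nothing available bears on the cause of these steps. Going by these compounds, whether oxygen itself matters, or the non-aromatic ring that carries it, remains open, and a methoxyphenyl group or a pyridine on the same chain carbon would address that question.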